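The compounds below may be only part of what the source reports. "The series", "measured", "known", "first", "only" and "open" are said of these compounds alone.

Measured compounds:
Compound 1, `COC(=O)C(=O)Nc1ccc(OC)c(=O)cc1` — 36%
Compound 2, `CCOC(=O)C(=O)Nc1c(Oc2ccccc2)ccccc1=O` — 0%
Compound 3, `CCOC(=O)C(=O)Nc1ccccc(Br)c1=O` — 52%

In a functional assay on the whole organism (strain Sprague-Dawley CD) for inhibition, with Rattus norvegicus as the target, read by paw edema, at a dose of 30 mg/kg by the intraperitoneal route (a lower number here means a weaker effect, a higher number a stronger effect of the compound at the dose given), compound 3 stands highest of the three numbers shown. Compound 1 comes nearest, with a number lower by a margin beyond the usual scatter, and compound 2 lies furthest, with a number lower by a margin well beyond it. Compound 3 is therefore the strongest of the three in this assay.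

The next compound, compound 4, `CCOC(=O)C(=O)Nc1ccccc(-c2ccccc2)c1=O`, keeps everything of compound 3 except one group. The change is phenyl in place of bromo on an aromatic carbon. Among the compounds with values here, no pair of the measured compounds differs by exactly this exchange, so the size of the step has to be guessed.

The expectation is a downward step in this assay, of a size beyond the scatter. Compound 2, which also carries a ring-containing group on its seven-membered ring, gives 0% in this assay. Compound 3, with bromo on its seven-membered ring, gives 52%. The step from compound 3 to compound 4 is estimated as a number 27 percentage points lower from compound 3 to compound 4 (beyond the scatter). For compound 4 the expected value in this assay is 25%, with a range from 0% to 50%.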

Compound 4, a percentage reported as inhibition, in the whole organism at one dose (the size of the read-out at that dose, not a potency): 72%
Estimate against measurement, compound 4: 47 percentage points below; the whole stated range lies below it.
By their numbers in this assay, from the lowest: compound 2; then compound 1; then compound 3; then compound 4.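

In this assay the exchange of bromo for phenyl brings a number 20 percentage points higher from compound 3 to compound 4 (beyond the scatter) on this aromatic carbon of a seven-membered aromatic ring of carbon only. Within the data shown here, this is the first step that can be read from one single change, and it shows that this position accepts far more than one heavy atom: a phenyl, with six heavy atoms and a six-membered aromatic ring of its own, stands where bromo stood, and the effect at this dose rises rather than falls. Nothing measured here accounts for the direction or size of this step.

Going by these compounds, what remains open is whether the ring of the phenyl matters or whether other groups on this same carbon would do as well, such as methyl, an amine, a carboxylic acid, a longer chain or a phenyl carrying a further group of its own. On these data alone, the step also describes the size of the effect at one dose, so how compound 3 and compound 4 compare in potency or at other doses stays unknown.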